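The source may report more compounds than this note shows. Statements on the series, on what has been measured and on what is new or still open speak of the compounds shown alone.

Measured so far:
Compound 1 `C=C[C@@](C)(CC[C@H]1C(C)=CC[C@H]2C(C)(C)CCC[C@]12C)O[C@@H]1O[C@@H](C)[C@@H](OC(C)=O)[C@H](O)[C@H]1O`: in a functional assay on A549 cells (Homo sapiens) for cytotoxicity, read by sulforhodamine B assay (a lower number here means that less compound is needed, a higher number that more compound is needed for the effect), compound 1 gives 3.2 ug/mL.
Compound 2 `C=C[C@](C)(O)CC[C@H]1C(=C)[C@H](O)C[C@H]2C(C)(C)CCC[C@]12C`: in this assay compound 2 reaches only > 5 ug/mL, which is a limit of the assay and not a number.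
Compound 3 `C=C[C@@](C)(CC[C@H]1C(C)=CC[C@H]2C(C)(C)CCC[C@]12C)O[C@@H]1O[C@H](C)[C@H](OC(C)=O)[C@H](O)[C@H]1O`: in this assay compound 3 gives 3.9 ug/mL.

Compound 1 holds the lowest of the two numbers; the nearest step is a 1.2-fold higher number from compound 1 to compound 3 (0.09 log units; within the scatter), a step that rests on (the fact that compounds 1 and 3 differ only in the configuration as drawn). Compound 4 `C=C[C@@](C)(CC[C@H]1C(C)=CC[C@H]2C(C)(C)CCC[C@]12C)O[C@@H]1O[C@@H](C)[C@@H](O)[C@H](O)[C@H]1O` differs from compound 1 by hydrogen in place of acetyl on an oxygen on a saturated carbon. Within the data shown here, no measured step exchanges an acetyl for a hydrogen; the only measured step, a 1.2-fold higher number from compound 1 to compound 3 (0.09 log units; within the scatter), changes configuration alone and stays within the scatter, so it gives no guide to the size of this change. With nothing bearing on it, no shift beyond the scatter is expected, though the range must stay wide. Compound 4 is therefore expected at 4.5 ug/mL, between 2 ug/mL and 12 ug/mL, an expected step of a 1.4-fold higher number from compound 1 to compound 4 (0.15 log units; within the scatter).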

Compound 4, concentration for half-maximal effect: 3.9 ug/mL
For compound 4 the middle estimate is 1.2-fold (0.06 log units) above the measured one; measured number inside the range.
By their numbers in this assay, from the lowest: compounds 1, 3 and 4 (each within the scatter of the next). At a limit, above all of these: compound 2.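

In this assay the exchange of acetoxy for hydroxy on this oxygen gives a 1.2-fold higher number from compound 1 to compound 4 (0.09 log units; within the scatter) and so counts as no measurable difference. The acetyl at this place is therefore not needed to hold the number of compound 1, which the step in configuration alone could not show.

Still open, on these data alone, is whether a benzoyl ester on this oxygen, or an amine in place of the hydroxy, would give a step beyond the scatter. No measurement shown bears on the reason for this flat step.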